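The compounds below may be only part of what the source reports. "The series", "measured", "known", "first", "only" and "open" are said of these compounds alone.

The series holds three compounds with entries in an ADME assay on a cell-free system (plasma, Homo sapiens) (on this read-out lower numbers stand for a smaller free fraction and higher numbers for a larger free fraction), and one still to be read. For compound 1 `CCNC(=O)Nc1nc2cc(-c3ccc(F)nc3)c(=O)n(C)c2s1` the entry is "not determined" (no result reported) and offers no number to work from. In this assay, among the measured compounds shown here, compound 2 `CCNC(=O)Nc1nc2cc(-c3cccnc3)c(=O)n(C(C)C)c2s1` gives 0.21 as the higher of the only two numbers available. In the same measurement compound 3 `CCNC(=O)Nc1nc2cc(-c3cccnc3)c(=O)n(CC3CC3)c2s1` gives 0.05 as the lower of the two.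

Compound 4 `CCNC(=O)Nc1nc2cc(-c3cccnc3)c(=O)n(CCC(C)C)c2s1` is reached from compound 3 by isobutyl in place of cyclopropyl on a saturated chain carbon bound to an aromatic nitrogen. Cut one bond further out, the same difference reads cyclopropylmethyl to isopentyl.

For the measured compounds named here, only one measured step bears on this change, cyclopropylmethyl in place of isopropyl on an aromatic nitrogen (a 4.2-fold lower number from compound 2 to compound 3 (0.62 log units; beyond the scatter)). Going by the values given here, that single step is thin support, and no measured pair compares an open chain with a ring at this place. A further small move downward in this assay is therefore expected, smaller than the measured step and possibly not clear of the scatter. The estimated change is a 1.7-fold lower number from compound 3 to compound 4 (0.22 log units; within the scatter) and remains only an expectation. Compound 4 is expected to read about 0.03 (estimated range 0.012 to 0.08).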

Compound 4, unbound fraction: 0.06
Estimate against measurement, compound 4: 2.0-fold (0.30 log units) below, and the stated range covers the measured number.
By their numbers in this assay, from the lowest: compounds 3 and 4 (each within the scatter of the next); then compound 2.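

In this assay, isobutyl in place of cyclopropyl on a saturated chain carbon bound to an aromatic nitrogen gives a 1.2-fold higher number from compound 3 to compound 4 (0.08 log units; within the scatter) and stays within the scatter, so this change leaves the two compounds indistinguishable on this read-out, and the three-membered ring is not needed for a reading of this size. Isopentyl in place of isopropyl on an aromatic nitrogen gives a 3.5-fold lower number from compound 2 to compound 4 (0.54 log units; beyond the scatter) and lies beyond the scatter, so a second group now stands apart from isopropyl, alongside the earlier 4.2-fold lower number from compound 2 to compound 3 (0.62 log units; beyond the scatter) step to cyclopropylmethyl. No supporting data on hand bear on why these groups read as they do.

The compounds shown leave open whether a chain longer than isopentyl, or one carrying an amine or a carboxylic acid, would shift the unbound fraction at this place. Equally open, as far as these compounds go, is whether a ring larger than cyclopropyl, such as cyclohexyl, would read with compound 3 and compound 4 or with compound 2.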